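Swapping the cyanophenyl for dimethylphenyl on the triazole nitrogen

The source may hold more compounds than are shown below. What is called first, only, known or untested is meant among the compounds shown, and "the series" means these compounds.

Of the compounds shown here, three built on a shared core have been measured in a functional assay on PC-12 cells (Rattus norvegicus) for cytotoxicity, read by MTT assay, with stated times of 2 h and 24 h, tested at 1 uM; on this read-out lower numbers stand for a weaker effect and higher numbers for a stronger effect at the one concentration tested. Compound 1 `CC(C)c1ccc(-n2nc(-c3ccc(C(F)(F)F)cc3O)nc2-c2ccccc2O)cc1` gives 69.7% in this assay, compound 2 `CC(C)(C)c1ccc(-n2nc(-c3ccc(C(F)(F)F)cc3O)nc2-c2ccccc2O)cc1` gives 67.3%, and compound 3 `N#Cc1ccc(-n2nc(-c3ccc(C(F)(F)F)cc3O)nc2-c2ccccc2O)cc1` gives 66.6%. All three numbers sit within the scatter of one another: the step of a number 2.4 percentage points lower from compound 1 to compound 2 (within the scatter) comes with methyl in place of hydrogen on a saturated chain carbon bound to an aromatic carbon and two saturated chain carbons, the step of a number 3.1 percentage points lower from compound 1 to compound 3 (within the scatter) with cyano in place of isopropyl on an aromatic carbon, and the step of a number 0.7 percentage points lower from compound 2 to compound 3 (within the scatter) with cyano in place of tert-butyl on an aromatic carbon. Compound 3 therefore stands at a number indistinguishable from those of compound 1 and compound 2.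

Compound 4 `Cc1ccc(-n2nc(-c3ccc(C(F)(F)F)cc3O)nc2-c2ccccc2O)c(C)c1` has not yet been measured. It differs from compound 3 by 2,4-dimethylphenyl in place of 4-cyanophenyl on an aromatic nitrogen. The two measured steps that change the group on that aromatic nitrogen, from compound 1 and from compound 2 to compound 3, both stayed within the scatter, so a step of the same kind is expected here: the estimated change is a number 1.4 percentage points higher from compound 3 to compound 4 (within the scatter), that is, none beyond the scatter. Compound 4 is accordingly expected to give 68%, with a range from 58% to 78%.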

Compound 4, a percentage reported as activity, at one concentration (the size of the read-out at that concentration, not a potency): 73.7%
For compound 4 the middle estimate is 5.7 percentage points below the measured one, and the stated range covers the measured number.
By their numbers in this assay, from the lowest: compounds 3, 2, 1 and 4 (each within the scatter of the next).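

In this assay the change to 2,4-dimethylphenyl on the aromatic nitrogen comes out as a number 7.1 percentage points higher from compound 3 to compound 4 (within the scatter) and as a number 6.4 percentage points higher from compound 2 to compound 4 (within the scatter) and as a number 4 percentage points higher from compound 1 to compound 4 (within the scatter), so the read-out stays within the scatter for all three comparisons. The earlier compounds varied only a single group on the phenyl ring, whereas compound 4 shows that this position also takes a ring with two methyl groups and neither the nitrile nor a branched chain, and the four aryl groups shown cannot be told apart at this one concentration. Nothing measured here accounts for the read-out at this position.

The compounds shown leave open whether a group of another kind on this phenyl ring, such as an amine or a carboxylic acid, or a saturated cyclohexyl ring in place of the phenyl, would move the read-out beyond the scatter. They also leave open how a single methyl group would behave, and whether changing the trifluoromethyl or either hydroxyl on the shared core would matter more than changing the group on the nitrogen.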